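Swapping the styryl arm for a biaryl in a bile acid receptor series

The source may report more compounds than this note shows. Statements on the series, on what has been measured and on what is new or still open speak of the compounds shown alone.

compound 1: `COC(=O)/C=C/c1cccc(N(Cc2ccc(/C=C/c3scnc3C)cc2)C(=O)C2CCCCC2)c1` — 227 nM
compound 2: `COC(=O)/C=C/c1cccc(N(Cc2ccc(-c3cc(Cl)ccc3OC)cc2)C(=O)C(C)C)c1` — 226 nM
compound 3: `COC(=O)/C=C/c1cccc(N(Cc2ccc(/C=C/c3ccc(OC)cc3)cc2)C(=O)C2CCCCC2)c1` — 208 nM

Of the compounds shown here, three sharing one core have been measured in an assay on isolated protein with Bile acid receptor (Homo sapiens) as the target; a lower number here means that less compound is needed, a higher number that more compound is needed for the effect. Compound 3 gives the smallest of the three numbers, but its nearest neighbour, compound 2, and its furthest, compound 1, both sit within the scatter of it, so no order among the three can be claimed.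

Compound 4 is `COC(=O)/C=C/c1cccc(N(Cc2ccc(-c3cc(Cl)ccc3OC)cc2)C(=O)C2CCCCC2)c1`. It differs from compound 3 in one place: 5-chloro-2-methoxyphenyl in place of 2-(4-methoxyphenyl)ethenyl on an aromatic carbon. Among the compounds with values here, the only measured step at this position, a 1.1-fold lower number from compound 1 to compound 3 (0.04 log units; within the scatter), exchanged one aryl group for another on the double-bonded chain and left the number essentially unchanged. Within the data shown here, the group entering in compound 4 is the one already carried by compound 2, whose value in this assay lies within the scatter of that of compound 3. Neither observation points to a shift beyond the scatter, so the step of a 1.1-fold higher number from compound 3 to compound 4 (0.02 log units; within the scatter) is expected to be small.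

Compound 4 is therefore estimated at 220 nM in this assay, with a range from 110 nM to 450 nM.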

Compound 4, half-maximal effective concentration: 233 nM
Estimate against measurement, compound 4: 1.1-fold (0.02 log units) below; low and high end bracket the measured number.
By their numbers in this assay, from the lowest: compounds 3, 2, 1 and 4 (each within the scatter of the next).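

In this assay, the exchange of 2-(4-methoxyphenyl)ethenyl for 5-chloro-2-methoxyphenyl on the aromatic carbon gave a step within the scatter (a 1.1-fold higher number from compound 3 to compound 4 (0.05 log units; within the scatter)), and the exchange of 2-(4-methyl-1,3-thiazol-5-yl)ethenyl for the same group did likewise (a 1.0-fold higher number from compound 1 to compound 4 (0.01 log units; within the scatter)), so this position now has a measured change that removes the double bond from the arm and still leaves the number within the scatter. Within the data shown here, with 5-chloro-2-methoxyphenyl in place, cyclohexyl in place of isopropyl on the carbonyl carbon also stayed within the scatter (a 1.0-fold higher number from compound 2 to compound 4 (0.01 log units; within the scatter)), which the earlier compounds could not show for that carbonyl substituent. No available evidence accounts for these small steps.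

On these data alone, all the groups compared at this position carry an aromatic ring, so it remains open whether an amine or a carboxylic acid there would move the number beyond the scatter. As far as these compounds go, it is equally open whether a longer chain in place of cyclohexyl on the carbonyl carbon would do so.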